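Swapping fluoro for methyl on the cyclopropyl ring

A few compounds are considered here, and "the series" means these few. Any claim that something is new, unique, unknown or untested is made for them only; others in the source may bear on it.

Compound 2, `O=C([C@@H]1C[C@@H]1F)N1CC2CC(C1)N2`, is the amide built from the shared core and a 2-fluorocyclopropyl group on the carbonyl carbon. Among the compounds with values here, in an assay on CHO cells for agonist activity at Neuronal acetylcholine receptor; alpha3/alpha6/beta2/beta3 (Homo sapiens), read by FLIPR and calcium flux (on this read-out higher numbers stand for larger maximal responses and lower numbers for smaller maximal responses), compound 2 gives 120%, the highest of the two numbers measured so far. Within the data shown here, its only neighbour is compound 1, `CC(=O)N1CC2CC(C1)N2`, which in this assay gives 100%; the step of a number 20 percentage points higher from compound 1 to compound 2 (beyond the scatter) came from putting 2-fluorocyclopropyl in place of methyl on the carbonyl carbon.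

Compound 3, `C[C@H]1C[C@H]1C(=O)N1CC2CC(C1)N2`, keeps the cyclopropyl ring but changes one substituent on it: methyl in place of fluoro on a saturated ring carbon. Among the measured compounds shown here, no measured step swaps fluoro for methyl anywhere on these compounds, so the step from compound 1 to compound 2 bears only indirectly: it shows that adding the substituted ring itself lifted the response by a modest amount, not what the fluorine contributed. With the ring retained, the expected step of a number 10 percentage points lower from compound 2 to compound 3 (within the scatter) is small, roughly within the scatter, in either direction. Compound 3 is therefore estimated at 110% in this assay, with a range from 90% to 130%.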

Compound 3, largest response reached (Emax), in percent of the reference or control that the assay uses: 60%
Compound 3: middle estimate off by 50 percentage points, on the high side; the measured number lies below the stated range.
By their numbers in this assay, from the lowest: compound 3; then compound 1; then compound 2.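

In this assay the group carried by the cyclopropyl ring counts for a great deal: methyl in place of fluoro on this saturated ring carbon gives a number 60 percentage points lower from compound 2 to compound 3 (beyond the scatter), so at this position the two groups are not interchangeable, even though each has only one heavy atom. The earlier compounds shown here suggested that a substituted ring on the carbonyl carbon might simply raise the maximal response, but 2-methylcyclopropyl in place of methyl gives a number 40 percentage points lower from compound 1 to compound 3 (beyond the scatter), the opposite direction to a number 20 percentage points higher from compound 1 to compound 2 (beyond the scatter), so the ring's effect depends on its substituent in these compounds. Nothing available here explains why exchanging fluoro for methyl lowers the response so sharply.

The compounds shown leave open where a plain cyclopropyl ring, with only hydrogens on this carbon, would fall relative to the fluoro and methyl versions, which would separate the contribution of the ring from that of its substituent. They also leave open how a hydroxyl, a chlorine or a longer chain such as ethyl on the same ring carbon would change the maximal response.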